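The source may hold more compounds than are shown below. What is called first, only, known or untested is meant among the compounds shown, and "the series" means these compounds.

Three members of the series have been run in a functional assay on MCF7 cells (Homo sapiens) for inhibition, read by sulforhodamine B assay, with a stated time of 48 h (a higher number here means that more compound is tolerated, a lower number that less compound is tolerated), so far. Compound 1 `COc1cc(-c2nn(-c3cccc(NC(=O)Nc4ccc(Cl)c(Cl)c4)c3)cc2-c2ccncc2)ccc1Cl` reaches only a limit of the assay, reported as > 50000 nM. Compound 2 `COc1cc(-c2nn(-c3cccc(NC(=O)c4ccc(Cl)c(C(F)(F)F)c4)c3)cc2-c2ccncc2)ccc1Cl` likewise gives only a limit, > 32500 nM. Compound 3 `COc1cc(-c2nn(-c3cccc(NC(=O)Nc4ccc(Cl)c(C(F)(F)F)c4)c3)cc2-c2ccncc2)ccc1Cl` also stands at a limit, > 32500 nM. With every value a limit, the step that the two limits leave unreadable from compound 1 to compound 2 cannot be read, and the same holds for a step that the two limits leave unreadable from compound 1 to compound 3 and for a step that the two limits leave unreadable from compound 2 to compound 3. Compound 3 therefore stands at the limit of > 32500 nM in this assay, at which 2 of the 3 values shown sit, while the remaining value sits at the limit of > 50000 nM in this assay, at which 1 of the 3 values shown sits; nothing in these numbers separates the three compounds.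

Compound 4 `COc1cc(-c2nn(-c3cccc(NC(=O)c4ccccc4)c3)cc2-c2ccncc2)ccc1Cl` is the next candidate. It differs from compound 3 by phenyl in place of (4-chloro-3-(trifluoromethyl)phenyl)amino on a carbonyl carbon, the change sitting on a carbonyl carbon whose other neighbour is an amide-type nitrogen. Within the data shown here, the one measured step of the same kind, a step that the two limits leave unreadable from compound 2 to compound 3, exchanges an arylamino group for an aryl group on that carbonyl carbon, but its size is not readable, so no measured step sets a scale for the present change. The expected step is a step that the limit leaves unreadable from compound 3 to compound 4, with no basis for a move beyond the scatter in this assay. Compound 4 is accordingly estimated at 40000 nM, within a range from 12000 nM to 120000 nM, most likely again reported as a limit.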

Compound 4, concentration lethal to 50% of the cells: > 100000 nM
Compound 4: a limit, no number; the forecaster's own chance of this, stated with the estimate: 75%; middle value at least 2.5-fold (0.39 log units) away from the limit.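

Compound 4 also stands at a limit, > 100000 nM. Among these compounds, with all four values in this assay being limits, no step between compound 4 and compound 1, compound 2 or compound 3 can be read. The compounds shown leave open whether any of the changes among them shifts the read-out at all.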